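The source may hold more compounds than are shown below. What is called first, only, known or untested is meant among the compounds shown, and "the series" means these compounds.

Series on the shared core of compound 1 `N#Cc1cc(F)cc(C(=O)Nc2ccccn2)c1`, whose amide-type nitrogen bears a pyridin-2-yl; in an in vitro functional assay on HEK293-A cells for antagonist activity at metabotropic glutamate receptor 5 (Rattus norvegicus), read by calcium flux (a lower number here means a stronger inhibitor, a higher number a weaker inhibitor), compound 1 gives 3010 nM. Compound 2 `N#Cc1cc(F)cc(C(=O)Nc2cccnc2)c1` carries pyridin-3-yl in its place. In this assay compound 2 reports only a limit, > 30000 nM. Compound 3 `N#Cc1cc(F)cc(C(=O)Nc2nccs2)c1` carries 1,3-thiazol-2-yl. In this assay compound 3 likewise reports only a limit, > 10000 nM. Compound 3 therefore stands on a limit and not on a number: the step of an at least 3.3-fold higher number from compound 1 to compound 3 (0.52 log units; beyond the scatter) is read against (the limit of > 10000 nM in this assay, at which 1 of the 3 values shown sits), and the step that the two limits leave unreadable from compound 2 to compound 3 cannot be sized. Compound 4 `N#Cc1cc(F)cc(C(=O)Nc2nc(C3CC3)cs2)c1` differs from compound 3 by cyclopropyl in place of hydrogen on an aromatic carbon. For the measured compounds named here, no measured step varies a substituent on the heteroaryl ring; the steps of an at least 9.9-fold higher number from compound 1 to compound 2 (0.99 log units; beyond the scatter) and an at least 3.3-fold higher number from compound 1 to compound 3 (0.52 log units; beyond the scatter) concern exchange of the whole ring and bear on this change only loosely. With compound 3 known solely as a limit, the expected step of an at least 2.0-fold lower number from compound 3 to compound 4 (0.30 log units; that floor lies within the scatter) rests on little. For compound 4 the estimate in this assay is 5000 nM, expected between 800 nM and 30000 nM, with a fair chance that only a limit is reported.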

Compound 4, half-maximal inhibitory concentration: 900 nM
Compound 4: the middle estimate sits 5.6-fold (0.74 log units) above what was measured; the range from low to high includes it.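

Cyclopropyl in place of hydrogen on the aromatic carbon next to the ring nitrogen gives an at least 11-fold lower number from compound 3 to compound 4 (1.04 log units; beyond the scatter), the first measured step in this assay that varies a substituent on the heteroaryl ring and not the whole ring. Compound 4 gives 900 nM, so the 1,3-thiazol-2-yl series now has a number and this position is shown to accept a carbon-only ring. Compound 3 remains a limit, so the true size of the step stays unknown and only its floor can be read: the limit of > 10000 nM in this assay, at which 1 of the 4 values shown sits.

With a single substituent at a single position, the step cannot be assigned to cyclopropyl in particular and not to any group at this carbon. Going by these compounds, a methyl, a tert-butyl or a dimethylamino group on the same carbon would test that, and the other ring carbon of the thiazole remains open.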